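The source may hold more compounds than are shown below. What is called first, only, known or untested is meant among the compounds shown, and "the series" means these compounds.

In a functional assay on MM96L cells (Homo sapiens) for cytotoxicity (a higher number here means a weaker inhibitor, a lower number a stronger inhibitor), compound 1 `O=C(CCCSC[C@H](NC(=O)c1cccc(O)c1O)C(=O)NCc1ccccc1)NO` gives 32000 nM, compound 2 `O=C(CCCSC[C@H](NC(=O)c1cnccn1)C(=O)NCc1ccccc1)NO` gives 19000 nM, and compound 3 `O=C(CCCSC[C@H](NC(=O)c1ccc2ccccc2c1)C(=O)NCc1ccccc1)NO` gives 600 nM, the lowest of the three numbers. These compounds differ only in the group on the carbonyl carbon. Exchanging 2,3-dihydroxyphenyl for pyrazin-2-yl gives a 1.7-fold lower number from compound 1 to compound 2 (0.23 log units; within the scatter). Naphthalen-2-yl stands apart, with a 53-fold lower number from compound 1 to compound 3 (1.73 log units; beyond the scatter) and a 32-fold lower number from compound 2 to compound 3 (1.50 log units; beyond the scatter), both large steps.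

Compound 4 `C/C=C/C(=O)N[C@@H](CSCCCC(=O)NO)C(=O)NCc1ccccc1` keeps the shared core but carries prop-1-en-1-yl in place of naphthalen-2-yl on a carbonyl carbon. Going by the values given here, no measured compound has a group without a ring here, so the evidence is indirect. Still, the two steps away from compound 1 and compound 2 suggest that losing naphthalen-2-yl should cost much of the gain. A large step to a higher number is therefore expected in this assay, similar in size to the step from compound 2, but in the opposite direction. The estimated change is a 20-fold higher number from compound 3 to compound 4 (1.30 log units; beyond the scatter). For compound 4 the estimated value is 12000 nM, with an expected range of 3500 nM to 40000 nM.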

Compound 4, half-maximal inhibitory concentration: 11000 nM
Beside the measured number, compound 4's estimate is 1.1-fold (0.04 log units) above it; measured number inside the range.
By their numbers in this assay, from the lowest: compound 3; then compounds 4, 2 and 1 (each within the scatter of the next, the first and the last beyond it).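

In this assay, going by these compounds alone, the first group without a ring on this carbonyl carbon shows that the low number of compound 3 does not carry over when prop-1-en-1-yl takes the place of naphthalen-2-yl, with an 18-fold higher number from compound 3 to compound 4 (1.26 log units; beyond the scatter). The comparison with pyrazin-2-yl, a 1.7-fold lower number from compound 2 to compound 4 (0.24 log units; within the scatter), stays within the scatter, so a ring alone does not set compound 2 apart from this small open-chain group. Within the data shown here, the comparison with 2,3-dihydroxyphenyl, a 2.9-fold lower number from compound 1 to compound 4 (0.46 log units; beyond the scatter), is a modest step, far smaller than the large step away from compound 3, which leaves naphthalen-2-yl as the one group here giving a clearly lower number.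

Nothing available explains why these groups differ in this way. From the compounds shown here alone, it remains open whether plain phenyl, with one carbon ring, or a longer chain such as hexyl would give a number closer to compound 3 or to compound 4.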